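Solubility notes on a urea series: pyrazole to oxazole

This account rests on a few compounds, and the source may have more. Where it says the series, first, only, none or still open, it means among the compounds named here.

Measured so far in a physicochemical assay for solubility, at pH 6.8; on this read-out lower numbers stand for lower solubility and higher numbers for higher solubility:
compound 1 `CC(C)(C)c1cc(NC(=O)n2ccc3cc(Oc4ncnc5c4CCNC5)ccc32)n[nH]1` gives 682000 nM
compound 2 `CC1(c2cc(NC(=O)n3ccc4cc(Oc5ncnc6c5CCNC6)ccc43)n[nH]2)CC1` gives 252000 nM
compound 3 `CC1(c2cc(NC(=O)n3ccc4cc(Oc5ncnc6c5CNC6)ccc43)n[nH]2)CC1` gives 489000 nM

Compound 3 lies within the scatter of both compound 1 and compound 2. Compound 4 `CC(C)c1cc(NC(=O)n2ccc3cc(Oc4ncnc5c4CNC5)ccc32)no1` differs from compound 3 by 5-isopropyl-1,2-oxazol-3-yl in place of 5-(1-methylcyclopropyl)-1H-pyrazol-3-yl on an amide-type nitrogen. For the measured compounds named here, no measured step covers this change; the nearest in place is a 2.7-fold lower number from compound 1 to compound 2 (0.43 log units; beyond the scatter), which touches the same ring but alters only the substituent, and a 1.9-fold higher number from compound 2 to compound 3 (0.29 log units; within the scatter) concerns the other end. As far as these compounds go, the change at the amide-type nitrogen is untested, so a step within the scatter or a modest one is expected, direction uncertain, leaning lower: for compound 4 an estimated 300000 nM (100000 nM to 900000 nM), a step of a 1.6-fold lower number from compound 3 to compound 4 (0.21 log units; within the scatter).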

Compound 4, solubility: 37000 nM
Beside the measured number, compound 4's estimate is 8.1-fold (0.91 log units) above it, and the stated range ends above it.
By their numbers in this assay, from the lowest: compound 4; then compounds 2, 3 and 1 (each within the scatter of the next, the first and the last beyond it).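

In this assay, for the compounds shown here, the group on the amide-type nitrogen is the first place to give a large step: 5-isopropyl-1,2-oxazol-3-yl in place of 5-(1-methylcyclopropyl)-1H-pyrazol-3-yl gives a 13-fold lower number from compound 3 to compound 4 (1.12 log units; beyond the scatter). The aromatic ring, the alkyl group and the hydrogen-bond donor count all change in this one step, so it cannot be assigned to any one of them. No supporting measurement speaks to the cause of this step.

Still open, as far as these compounds go, is how 5-isopropyl-1H-pyrazol-3-yl or 5-(1-methylcyclopropyl)-1,2-oxazol-3-yl would read, which would separate ring from alkyl group. Also open, from the compounds shown here alone, is how a group carrying an amine would read at this place.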